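Replacing a Methyl with Pentafluoroethyl: Expected Permeability Gain

This account rests on a few compounds, and the source may have more. Where it says the series, first, only, none or still open, it means among the compounds named here.

Compound 1 `Cc1ncc(Cc2nc(-c3nc(C(F)(F)F)n[nH]3)n3ccccc23)cn1`: 27 10^-6 cm/s
Compound 2 `Cc1n[nH]c(-c2nc(Cc3ccccc3F)c3ccccn23)n1`: 1 10^-6 cm/s
Compound 3 `Fc1ccccc1Cc1nc(-c2nc(C(F)(F)F)n[nH]2)n2cccnc12`: 28 10^-6 cm/s

These three compounds were measured in an ADME assay on MDCKII-LE cells (Canis lupus familiaris) for permeability, in the apical to basolateral direction; a higher number here means that the compound crosses the layer faster, a lower number that the compound crosses the layer more slowly. Compound 2 stands lowest of the three: in this assay compound 2 gives 1 10^-6 cm/s, whereas compound 1 gives 27 10^-6 cm/s and compound 3 gives 28 10^-6 cm/s, both beyond the scatter above compound 2. For the measured compounds named here, compounds 1 and 3 each carry a trifluoromethyl group where compound 2 carries a methyl, though they are not single-change partners of compound 2 and no step between them is counted.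

Compound 4 `Fc1ccccc1Cc1nc(-c2nc(C(F)(F)C(F)(F)F)n[nH]2)n2ccccc12` has not yet been measured in this assay. It differs from compound 2 as follows: 1,1,2,2,2-pentafluoroethyl in place of methyl on an aromatic carbon

A large upward step from compound 2 to compound 4 in this assay is expected, beyond the scatter, because compound 3 gives 28 10^-6 cm/s and compound 1 gives 27 10^-6 cm/s. For compound 4 the estimated value in this assay is 25 10^-6 cm/s, with a range from 8 10^-6 cm/s to 50 10^-6 cm/s, which corresponds to an expected step of a 25-fold higher number from compound 2 to compound 4 (1.40 log units; beyond the scatter).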

Compound 4, apparent permeability in the MDCKII-LE assay: 3 10^-6 cm/s
The estimate for compound 4 lay 8.3-fold (0.92 log units) above the measured number, outside the stated range (below it).
By their numbers in the MDCKII-LE assay, from the lowest: compound 2; then compound 4; then compounds 1 and 3 (each within the scatter of the next).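

In the MDCKII-LE assay, putting 1,1,2,2,2-pentafluoroethyl in place of methyl on this aromatic carbon gives a 3.0-fold higher number from compound 2 to compound 4 (0.48 log units; beyond the scatter). For the compounds shown here, this is the first single-change comparison at this place, and it shows a real but modest gain from adding this larger fluorinated chain. In a physicochemical assay for lipophilicity, measured as octanol-water partition, at pH 7.4 (a higher number here means a more lipophilic compound, a lower number a more polar compound), compound 2 gives 3.3 and compound 4 gives 4.2, so the same change moves both read-outs upward.

One pair of compounds cannot tell whether the two rises are linked, or whether the fluorine atoms or simply the larger chain account for them. From the compounds shown here alone, it also remains open how a plain ethyl group, a longer chain without fluorine or an amine would behave on this same carbon.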